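The compounds below may be only part of what the source reports. "The series", "measured", "known", "first", "only" and "open" are said of these compounds alone.

Measured so far:
compound 1, `CCC(C)C(NC(=O)n1nnc2ccccc21)C(=O)NCc1ccccc1`: 200 ug/mL
compound 2, `CC(C)C(NC(=O)n1nnc2ccccc21)C(=O)NC1CCCC1`: > 200 ug/mL

Compound 1, `CCC(C)C(NC(=O)n1nnc2ccccc21)C(=O)NCc1ccccc1`, was tested in a functional assay on HEL cells (Homo sapiens) for cytotoxicity (a higher number here means that more compound is tolerated, a lower number that less compound is tolerated), and gave 200 ug/mL. Compound 2, `CC(C)C(NC(=O)n1nnc2ccccc21)C(=O)NC1CCCC1`, was tested in the same way. In this assay compound 2 reaches > 200 ug/mL, which is a limit of the assay and not a number. This is the limit of > 200 ug/mL in this assay, at which 1 of the 2 values shown sits.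

Compound 3, `CCC(C)C(NC(=O)n1nnc2ccccc21)C(=O)NC1CCCC1`, has not yet been measured. It differs from compound 2 by methyl in place of hydrogen on a saturated chain carbon, three bonds along the chain from an amide-type nitrogen and a carbonyl carbon. Compound 1 already carries the sec-butyl group together with a number in this assay, and compound 2 with isopropyl gives only the limit, so the two values give no sign of a real shift. The step is expected to stay within the scatter: a number no higher from compound 2 to compound 3 (the limit leaves the size open). Compound 3 is therefore estimated at 200 ug/mL in this assay, with a range from 100 ug/mL to 400 ug/mL.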

Compound 3, minimum cytotoxic concentration: >= 80 ug/mL
Compound 3: only a limit was reported; the forecaster's own chance of this, stated with the estimate: 55%; the middle value lies beyond the limit too.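

In this assay compound 3 gives >= 80 ug/mL, which is a limit of the assay and not a number. Compound 2 also stands at a limit, so the steps to compound 3 from compound 2 and from compound 1 cannot be read. The compounds shown leave open whether going from isopropyl to sec-butyl, or from benzyl to cyclopentyl, shifts the result in this assay at all.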